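Amide analogue of compound 2: note on compound 3

A few compounds are considered here, and "the series" means these few. Any claim that something is new, unique, unknown or untested is made for them only; others in the source may bear on it.

Measured so far:
compound 1 `COc1cc(Cl)cc(-c2nn(-c3cccc(NC(=O)c4ccc(Cl)c(Cl)c4)c3)cc2-c2ccncc2)c1` gives in a functional assay on IGROV-1 cells (Homo sapiens) for inhibition, read by sulforhodamine B assay, with a stated time of 48 h, tested at 10 uM (a higher number here means a weaker effect of the compound at the concentration tested, a lower number a stronger effect), 71.6%
compound 2 `COc1cc(Cl)cc(-c2nn(-c3cccc(NC(=O)Nc4cccc(C(F)(F)F)c4)c3)cc2-c2ccncc2)c1` gives in this assay 28.9%

In this assay, for the measured compounds named here, compound 2 stands lowest of the two numbers; the only measured step, a number 42.7 percentage points lower from compound 1 to compound 2 (beyond the scatter), is large. Compound 3 `COc1cc(Cl)cc(-c2nn(-c3cccc(NC(=O)c4cccc(C(F)(F)F)c4)c3)cc2-c2ccncc2)c1` differs from compound 2 by 3-(trifluoromethyl)phenyl in place of (3-(trifluoromethyl)phenyl)amino on a carbonyl carbon. Going by the values given here, that measured step altered both the aryl group and the carbonyl neighbour at once, so it bears on this change only loosely, and no step isolates removal of the amino link. An upward step is expected, a number 21.1 percentage points higher from compound 2 to compound 3 (beyond the scatter), since compound 1, the other carbonyl-linked aryl amide, gave 71.6%. For compound 3 the estimate is 50%, within 25% to 78%.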

Compound 3, a percentage reported as activity, at one concentration (the size of the read-out at that concentration, not a potency): 80.7%
Compound 3: the middle estimate sits 30.7 percentage points below what was measured; measured number above the stated range.
By their numbers in this assay, from the lowest: compound 2; then compounds 1 and 3 (each within the scatter of the next).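

With the 3-(trifluoromethyl)phenyl group kept on the carbonyl carbon, taking out the amino link isolates this change in this assay: a number 51.8 percentage points higher from compound 2 to compound 3 (beyond the scatter) is a large step. Between the two amides, by contrast, a number 9.1 percentage points higher from compound 1 to compound 3 (within the scatter) shows no separable effect of exchanging the aryl group. Among these three compounds the stronger effect thus appears only with the amino link, in compound 2, and nothing available explains it.

Open, on these data alone, is whether a methylamino or an oxygen link on the carbonyl carbon would retain that effect, and whether (3,4-dichlorophenyl)amino would match (3-(trifluoromethyl)phenyl)amino.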